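The source may hold more compounds than are shown below. What is called first, only, known or untested is meant among the compounds shown, and "the series" means these compounds.

Compound 1 `CCn1nc(C(=O)N[C@H]2COc3ccccc3N(C)C2=S)nc1Cc1ccccc1` gives 17 nM in a functional assay on HT-29 cells (Homo sapiens) for inhibition, read by luminescence and CellTiter-Glo, with a stated time of 24 h; on this read-out lower numbers stand for an effect already at smaller amounts and higher numbers for an effect only at larger amounts of compound. Compound 2 `CN1C(=S)[C@@H](NC(=O)c2nc(Cc3ccccc3)n(CCCC#N)n2)COc2ccccc21` gives 2400 nM, and compound 3 `CN1C(=S)[C@@H](NC(=O)c2nc(Cc3ccccc3)n(CCCCCC#N)n2)COc2ccccc21` gives 3830 nM, the highest of the three numbers; it sits a 1.6-fold higher number from compound 2 to compound 3 (0.20 log units; within the scatter) from compound 2 and a 230-fold higher number from compound 1 to compound 3 (2.35 log units; beyond the scatter) from compound 1. Compound 4 `CN1C(=S)[C@@H](NC(=O)c2nc(Cc3ccccc3)n(CC3CCOC3)n2)COc2ccccc21` differs from compound 3 by oxolan-3-yl in place of 4-cyanobutyl on a saturated chain carbon bound to an aromatic nitrogen. For the measured compounds named here, two measured steps bear on this place on the chain: a 140-fold higher number from compound 1 to compound 2 (2.15 log units; beyond the scatter) and a 230-fold higher number from compound 1 to compound 3 (2.35 log units; beyond the scatter) both show that a nitrile-bearing group there raised the number strongly, while a 1.6-fold higher number from compound 2 to compound 3 (0.20 log units; within the scatter) shows that exchanging one such group for another changed little. Going by the values given here, no measured pair swaps a chain for a ring, so the direction for compound 4 is open. Compound 4 is expected to give 1500 nM, between 300 nM and 8000 nM. The step of a 2.6-fold lower number from compound 3 to compound 4 (0.41 log units; beyond the scatter) is expected to stay near the scatter.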

Compound 4, half-maximal effective concentration: 4420 nM
For compound 4 the middle estimate is 2.9-fold (0.47 log units) below the measured one; the range from low to high includes it.
By their numbers in this assay, from the lowest: compound 1; then compounds 2, 3 and 4 (each within the scatter of the next).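

In this assay, the step of a 1.2-fold higher number from compound 3 to compound 4 (0.06 log units; within the scatter) and the step of a 1.8-fold higher number from compound 2 to compound 4 (0.27 log units; within the scatter) put the ring-bearing oxolan-3-yl group level with the nitrile chains. The step of a 260-fold higher number from compound 1 to compound 4 (2.41 log units; beyond the scatter) is as large as those seen with the nitrile chains, so among these compounds a high number at this place does not need a nitrile or an open chain. Only compound 1, with methyl in place of the group carried by the others, stands apart.

Going by these compounds, whether an amine or a carboxylic acid here would sit near compound 1 or with the others stays open. Nothing available explains why these different groups give such similar numbers.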